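The compounds below may be only part of what the source reports. "The series", "measured", "known", "first", "only" and "open" are said of these compounds alone.

Compound 1 `CCOC(=O)N1CCN(C(=O)c2nc(Nc3cc(C4CC4)[nH]n3)c3cc(Cl)ccc3n2)C[C@H]1C`: 97.7% in a physicochemical assay, read by HPLC, in phosphate buffer, with a stated time of 2 h, at pH 7.4; a higher number here means that more of the compound is left, a lower number that less of the compound is left
Compound 2 `C[C@@H]1CN(C(=O)c2nc(Nc3cc(C4CC4)[nH]n3)c3cc(Cl)ccc3n2)CCN1C(=O)OC(C)(C)C`: 99.1%
Compound 3 `CC(OC(=O)C(C)C)OC(=O)N1CCN(C(=O)c2nc(Nc3cc(C4CC4)[nH]n3)c3cc(Cl)ccc3n2)C[C@H]1C`: 96.6%

Compound 3 stands lowest of the three in this assay, with compound 1 nearest and compound 2 furthest, both gaps within the scatter. Compound 4 `CC(C)OC(=O)N1CCN(C(=O)c2nc(Nc3cc(C4CC4)[nH]n3)c3cc(Cl)ccc3n2)C[C@H]1C` differs from compound 3 by methyl in place of (isopropylcarbonyl)oxy on a saturated chain carbon bound to an oxygen next to a carbonyl group and a saturated chain carbon. Among the compounds with values here, the steps that bear on this change at the same oxygen are a number 1.4 percentage points higher from compound 1 to compound 2 (within the scatter) and a number 2.5 percentage points lower from compound 2 to compound 3 (within the scatter), and the closely related a number 1.1 percentage points lower from compound 1 to compound 3 (within the scatter); none of them moved beyond the scatter, so no shift beyond the scatter is expected for compound 4 either. Compound 4 is therefore estimated to show a number 1.4 percentage points higher from compound 3 to compound 4 (within the scatter), giving an expected value of 98% with a range from 94% to 100%.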

Compound 4, percent of the compound remaining: 99%
Compound 4: the middle estimate sits 1 percentage points below what was measured; the measured number falls inside the stated range.
By their numbers in this assay, from the lowest: compounds 3, 1, 4 and 2 (each within the scatter of the next).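

In this assay, methyl in place of (isopropylcarbonyl)oxy on the saturated chain carbon gave a number 2.4 percentage points higher from compound 3 to compound 4 (within the scatter), so the simpler isopropoxycarbonyl group reads the same as the larger group. The same carbon was also tested with one methyl fewer or more: hydrogen in place of methyl gave a number 0.1 percentage points lower from compound 2 to compound 4 (within the scatter), and methyl in place of hydrogen gave a number 1.3 percentage points higher from compound 1 to compound 4 (within the scatter). All four groups on this oxygen therefore stay within the scatter of each other. Nothing available explains this. On these data alone, whether an amine or a carboxylic acid on this chain would hold the same reading remains open.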